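The source may report more compounds than this note shows. Statements on the series, on what has been measured and on what is new or still open speak of the compounds shown alone.

Measured so far in an assay on isolated protein for inhibition of Ectonucleotide pyrophosphatase/phosphodiesterase family member 1 (Homo sapiens), tested at 10 uM; on this read-out higher numbers stand for more inhibition at the one concentration tested (going by the name of the read-out) and lower numbers for less inhibition:
compound 1, `COc1ccc(NC(=O)CSc2nc3ccc(N4CCN(C)CC4)nc3[nH]2)cc1OC`, gives 35%
compound 2, `COc1ccc(NC(=O)CSc2nc3ccc(N(C)C)nc3[nH]2)cc1OC`, gives 58%
compound 3, `COc1ccc(NC(=O)CSc2nc3ccc(N4CCCCC4)nc3[nH]2)cc1OC`, gives 27%

Compound 3 sits at the bottom of the three numbers, but only one gap is real: a number 31 percentage points lower from compound 2 to compound 3 (beyond the scatter) lies beyond the scatter, whereas a number 8 percentage points lower from compound 1 to compound 3 (within the scatter) does not, so compound 3 and compound 1 cannot be told apart.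

Compound 4, `COc1ccc(NC(=O)CSc2nc3ccc(OCC(F)(F)F)nc3[nH]2)cc1OC`, changes the same position: 2,2,2-trifluoroethoxy in place of piperidin-1-yl on an aromatic carbon. Within the data shown here, no measured step exchanges a ring amine for an ether, so the two steps ending at compound 3 are the only guide, and they show that swapping this group shifts the number anywhere from nothing to a large amount. A step of a number 3 percentage points higher from compound 3 to compound 4 (within the scatter) is therefore expected for compound 4, with no confident direction. Compound 4 is estimated at 30%, within 8% to 55%.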

Compound 4, a percentage reported as inhibition, at one concentration (the size of the read-out at that concentration, not a potency): 61%
Compound 4: the middle estimate sits 31 percentage points below what was measured; measured number outside the range, above it.
By their numbers in this assay, from the lowest: compounds 3 and 1 (each within the scatter of the next); then compounds 2 and 4 (each within the scatter of the next).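

In this assay the number is higher with a group with no amine nitrogen at the position than with either ring amine, and 2,2,2-trifluoroethoxy shows a number 34 percentage points higher from compound 3 to compound 4 (beyond the scatter) and a number 26 percentage points higher from compound 1 to compound 4 (beyond the scatter) while a number 3 percentage points higher from compound 2 to compound 4 (within the scatter) applies against dimethylamino. Piperidin-1-yl and 2,2,2-trifluoroethoxy have the same heavy-atom count, so that count alone does not set the number here, and across these four compounds the two groups without a ring give the higher numbers. Nothing available explains these steps.

On these data alone, whether the fluorine matters remains open, since a plain ethoxy would test that. Also open, as far as these compounds go, is whether a morpholine ring stays with the low ring amines.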